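Adding a Hydroxy to the Chain of Compound 3

The source may report more compounds than this note shows. Statements on the series, on what has been measured and on what is new or still open speak of the compounds shown alone.

Compound 3 `CC(=O)Nc1cc(O)ccc1O` is the smallest member of this set, with two hydroxy groups on its core. In a functional assay on cells (Homo sapiens) for cytotoxicity, read by MTT assay, with a stated time of 48 h (on this read-out lower numbers stand for stronger inhibition and higher numbers for weaker inhibition), compound 3 gives 35000 nM. Compound 1 `CN(CC(=O)Nc1cc(O)ccc1O)c1ccccc1` has the same core but a larger group on the chain; in this assay compound 1 gives 6000 nM, so compound 3 stands as the higher of the two plain numbers. Compound 2 `CN(CC(=O)Nc1cccc(O)c1)c1ccccc1` lacks one hydroxy on an aromatic carbon. In this assay compound 2 reaches only the limit > 100000 nM, not a number. Among the measured compounds shown here, the single measured step, an at least 16-fold higher number from compound 1 to compound 2 (1.22 log units; beyond the scatter), concerns a hydroxy on an aromatic carbon rather than the chain, and it rests on (the limit of > 100000 nM in this assay, at which 1 of the 3 values shown sits).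

Compound 4 `O=C(CO)Nc1cc(O)ccc1O` is compound 3 changed by hydroxy in place of hydrogen on a saturated chain carbon bound to a carbonyl carbon. For the measured compounds named here, no measured step touches this chain position, so the step expected here, a 1.4-fold lower number from compound 3 to compound 4 (0.15 log units; within the scatter), is modest and points toward a somewhat lower number, the only hint being compound 1 with its 6000 nM and a larger chain group. Compound 4 is therefore expected to give 25000 nM, between 8000 nM and 80000 nM.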

Compound 4, half-maximal inhibitory concentration: 12000 nM
For compound 4 the middle estimate is 2.1-fold (0.32 log units) above the measured one, and the stated range covers the measured number.
By their numbers in this assay, from the lowest: compounds 1 and 4 (each within the scatter of the next); then compound 3. At a limit, above all of these: compound 2.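

Among the compounds shown here, until now the only measured step concerned a hydroxy on an aromatic carbon, so nothing showed whether the chain responds to change at all. In this assay the change from methyl to hydroxymethyl, on a saturated chain carbon bound to a carbonyl carbon, gives a 2.9-fold lower number from compound 3 to compound 4 (0.46 log units; beyond the scatter) and so shows that this position does affect the read-out, with only one heavy atom entering. Nothing measured among these compounds says why the number moves at this position.

The compounds shown leave open whether the hydroxy itself is needed here or whether another group on the same chain carbon, such as an amine, a methoxy or a carboxylic acid, would move the number in the same way. They also leave open what a longer chain carrying the hydroxy would give.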